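Fluoro for trifluoromethyl on an aromatic carbon

The compounds below may be only part of what the source reports. "The series", "measured", "known", "first", "only" and "open" are said of these compounds alone.

Measured compounds:
- Compound 1 `C=C1C[C@]23C[C@@]1(O)CC[C@H]2c1ccc(OS(=O)(=O)c2ccc(C)cc2)c(C)c1[C@@H]3Cn1cc(-c2ccc(OC)cc2)nn1` reaches only the limit > 20000 nM in a functional assay on SW480 cells (Homo sapiens) for cytotoxicity, read by MTT assay, with a stated time of 4 days; on this read-out higher numbers stand for weaker inhibition and lower numbers for stronger inhibition.
- Compound 2 `C=C1C(=O)[C@]23C[C@@]1(O)CC[C@H]2c1ccc(O)c(C)c1[C@@H]3Cn1cc(-c2ccc(C(F)(F)F)cc2)nn1` gives 370 nM in this assay.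
- Compound 3 `C=C1C[C@]23C[C@@]1(O)CC[C@H]2c1ccc(O)c(C)c1[C@@H]3Cn1cc(-c2ccccn2)nn1` reaches only the limit > 20000 nM in this assay.

For the measured compounds named here, compound 2 holds the only real number among the three; the other two stand at the limit of > 20000 nM in this assay, at which 2 of the 3 values shown sit. Compound 4 `C=C1C(=O)[C@]23C[C@@]1(O)CC[C@H]2c1ccc(O)c(C)c1[C@@H]3Cn1cc(-c2ccc(F)cc2)nn1` differs from compound 2 by fluoro in place of trifluoromethyl on an aromatic carbon. Going by the values given here, no pair of measured compounds differs in one place, so no measured step guides this change. The step of a 2.2-fold higher number from compound 2 to compound 4 (0.33 log units; beyond the scatter) is expected to be a modest weakening, somewhat beyond the scatter. Compound 4 is therefore expected to give 800 nM, with a range of 250 nM to 3000 nM in this assay.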

Compound 4, half-maximal inhibitory concentration: 250 nM
Beside the measured number, compound 4's estimate is 3.2-fold (0.51 log units) above it, within the range that was stated.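

In this assay, the change on an aromatic carbon para to a large group gives a 1.5-fold lower number from compound 2 to compound 4 (0.17 log units; within the scatter). For the compounds shown here, this is the first one-place comparison, and it shows that 4-(trifluoromethyl)phenyl and 4-fluorophenyl cannot be told apart at this position. Nothing given here accounts for this result. As far as these compounds go, whether an amine or a carboxylic acid at this same aromatic carbon would keep the value in this range remains open. So does whether the same exchange would behave alike on the core of compound 1.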